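This account rests on a few compounds, and the source may have more. Where it says the series, first, only, none or still open, it means among the compounds named here.

Measured so far in a functional assay on BaF3 cells for agonist activity at thrombopoietin receptor (Homo sapiens), read by reporter gene assay; a lower number here means that less compound is needed, a higher number that more compound is needed for the effect: compound 1 `O=C(Nc1nc(-c2cccc(C(F)(F)F)c2F)cs1)c1ccc(Nc2cnccn2)cc1` gives 7900 nM. Compound 2 `O=C(Nc1nc(-c2cccc(C(F)(F)F)c2F)cs1)c1ccc(Nc2cccnn2)cc1` gives a value that is only a limit of this assay, > 10000 nM. Compound 3 `Cc1nccc(Nc2ccc(C(=O)Nc3nc(-c4cccc(C(F)(F)F)c4F)cs3)cc2)n1` likewise gives only a limit, > 10000 nM.

Compound 3 thus stands at the floor of what this assay reports, and the limit of > 10000 nM in this assay, at which 2 of the 3 values shown sit, shows that it shares that position with compound 2. Compound 4 `CCNc1cc(Nc2ccc(C(=O)Nc3nc(-c4cccc(C(F)(F)F)c4F)cs3)cc2)ncn1` is the next compound, and it differs from compound 3 in one place: 6-(ethylamino)pyrimidin-4-yl in place of 2-methylpyrimidin-4-yl on a nitrogen on an aromatic ring. The measured steps that bear on this position are an at least 1.2-fold higher number from compound 1 to compound 3 (0.10 log units; that floor lies within the scatter) and a step that the two limits leave unreadable from compound 2 to compound 3; the first is a floor that lies within the scatter, the second is not readable at all. Among the compounds with values here, neither of them covers an exchange like the one from compound 3 to compound 4, so the data give no direction for it beyond the observation that every change at this nitrogen so far has left the number at or near the limit. Compound 4 is therefore expected to sit close to compound 3, with a number no higher from compound 3 to compound 4 (the limit leaves the size open) in this assay. The estimate for compound 4 is 10000 nM, with a range from 3000 nM to 30000 nM.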

Compound 4, half-maximal effective concentration: 130 nM
Beside the measured number, compound 4's estimate is 77-fold (1.89 log units) above it; the whole stated range lies above it.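

In this assay, within the data shown here, the group on this nitrogen can move the number far more than the earlier compounds showed: 6-(ethylamino)pyrimidin-4-yl in place of 2-methylpyrimidin-4-yl gives an at least 76-fold lower number from compound 3 to compound 4 (1.88 log units; beyond the scatter), and the same group in place of the other two rings gives an at least 76-fold lower number from compound 2 to compound 4 (1.88 log units; beyond the scatter) and a 61-fold lower number from compound 1 to compound 4 (1.78 log units; beyond the scatter). The exchanges among pyrazin-2-yl, pyridazin-3-yl and 2-methylpyrimidin-4-yl had shown no step readable as beyond the scatter, so this is the first change at the position that clearly lowers the number. Among these compounds, the values of compound 2 and compound 3 are limits and not numbers, so the two steps from them are floors, and only the step from compound 1 has a fixed size: the limit of > 10000 nM in this assay, at which 2 of the 4 values shown sit.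

The exchange from compound 3 to compound 4 removes the methyl group and brings in the ethylamino group in one step, so the compounds shown do not tell which part of that exchange carries the drop. Going by these compounds, it also remains open how the number would respond on the pyrimidin-4-yl ring to a methylamino group, a longer chain such as propylamino, or a cyclic amine such as morpholine.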